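The source may report more compounds than this note shows. Statements on the series, on what has been measured and on what is new or still open speak of the compounds shown alone.

Measured in a functional assay on NCI-H460 cells (Homo sapiens) for inhibition, with a stated time of 72 h; a lower number here means a stronger inhibitor, a higher number a weaker inhibitor:
- compound 1 `COc1cc(C(=O)c2cccc3cc[nH]c23)cc(OC)c1OC`: 295 nM
- compound 2 `COc1cc(C(=O)c2cccc3c2ccn3C)cc(OC)c1OC`: 28.8 nM
- compound 3 `COc1cc(C(=O)c2ccc3c(ccn3C)c2)cc(OC)c1OC`: 14.1 nM

Compound 3 holds the lowest number of the three at 14.1 nM. Compound 2 and compound 1 both lie higher, each beyond the scatter, and compound 1 is much the further away.

The next compound is compound 4 `COc1cc(C(=O)c2ccc3c(ccn3C(C)C)c2)cc(OC)c1OC`, which carries isopropyl in place of methyl on an aromatic nitrogen of a five-membered aromatic ring with 1 nitrogen (isopropyl in place of methyl on an aromatic nitrogen). Within the data shown here, no pair measured so far differs in one place only, so the series gives no direct reading on this change, and the expectation below is a judgement from the structural change alone.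

A moderate loss in this assay is expected, beyond the scatter and towards a higher number, rather than a gain. The estimated change is a 4.3-fold higher number from compound 3 to compound 4 (0.63 log units; beyond the scatter). For compound 4 the estimated value is 60 nM, with an expected range of 15 nM to 300 nM.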

Compound 4, half-maximal inhibitory concentration: 1600 nM
Compound 4: the middle estimate sits 27-fold (1.43 log units) below what was measured; measured number above the stated range.
By their numbers in this assay, from the lowest: compound 3; then compound 2; then compound 1; then compound 4.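

In this assay, among these compounds, isopropyl in place of methyl on the aromatic nitrogen gives a 110-fold higher number from compound 3 to compound 4 (2.05 log units; beyond the scatter) and so provides the first step that can be read at a single place. The change is large, which shows that potency at this nitrogen depends strongly on the group it carries, and that methyl is far preferred over isopropyl on the core of compound 3. No measurement at hand accounts for the loss.

Still open, going by these compounds, is whether the loss follows the branching of isopropyl or simply its carbon count, a question that ethyl or a straight propyl chain on the same nitrogen would address. Also open, on these data alone, is how a hydroxyethyl or aminoethyl chain at this position would read in this assay.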